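This account rests on a few compounds, and the source may have more. Where it says the series, first, only, none or still open, it means among the compounds named here.

Measured compounds:
compound 1 `CCCCN(CCCC)CCCCOc1ccc(S(=O)(=O)c2c(C(C)C)cn3ccccc23)cc1` — 20.2 nM
compound 2 `COc1ccc(CN(C)CCCOc2ccc(S(=O)(=O)c3c(C(C)C)cn4ccccc34)cc2)cc1OC` — 3.18 nM

Of the compounds shown here, two sharing the same core have been tested in a functional assay (aorta) with Rattus norvegicus as the target; on this read-out lower numbers stand for stronger inhibition and higher numbers for weaker inhibition. In this assay compound 1 gives 20.2 nM, while compound 2 gives 3.18 nM. Compound 2 therefore stands at the lower of the two numbers, and compound 1 sits higher by a margin that lies beyond the scatter of repeated measurements. For the measured compounds named here, the two compounds differ in more than one place, so no single step between them is defined; their two values show only that the amine side chain of compound 2 goes with the stronger inhibition of the pair.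

Compound 3 `CC(C)c1cn2ccccc2c1S(=O)(=O)c1ccc(OCCCN(C)C)cc1` has not yet been measured in this assay. Relative to compound 2 the change is hydrogen in place of 3,4-dimethoxyphenyl on a saturated chain carbon bound to an amine nitrogen. The loss of the 3,4-dimethoxybenzyl group in favour of methyl strips away a considerable portion of the side chain, and the account expects this to be reflected as a step toward weaker inhibition, of a size beyond the scatter, as a 19-fold higher number from compound 2 to compound 3 (1.28 log units; beyond the scatter). Compound 3 is accordingly estimated at 60 nM, within a range from 15 nM to 250 nM.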

Compound 3, half-maximal inhibitory concentration: 390 nM
Beside the measured number, compound 3's estimate is 6.5-fold (0.81 log units) below it, and the stated range ends below it.
By their numbers in this assay, from the lowest: compound 2; then compound 1; then compound 3.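

In this assay, the exchange of the 3,4-dimethoxybenzyl group for methyl on the amine nitrogen gives a 120-fold higher number from compound 2 to compound 3 (2.09 log units; beyond the scatter), a large step that shows how much of the inhibition in this pair goes with that group. The dimethylamino side chain also falls well short of the dibutylamino side chain, with a 19-fold higher number from compound 1 to compound 3 (1.29 log units; beyond the scatter), so compound 3 stands as the weakest of the three and two very different larger amine side chains both go with stronger inhibition. Nothing measured here gives a reason for either step.

Which part of the 3,4-dimethoxybenzyl group carries the step remains open: a plain benzyl group or a benzyl group with a single methoxy on its ring would separate the contribution of the ring from that of its methoxy groups. Also open, from the compounds shown here alone, is how the large step from compound 1 divides between the butyl groups and the length of the chain: a dibutylamino group on the chain of compound 3, or a dimethylamino group on the longer chain of compound 1, would tell the two apart.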